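From isopropyl ester to ethyl ester: an expected step

The compounds below may be only part of what the source reports. "The series", "measured", "known", "first", "only" and "open" are said of these compounds alone.

Compound 1 `CC(C)OC(=O)C(C)ON1C(=O)c2ccccc2C1=O` is an ester of a shared core; in a functional assay on the whole organism for inhibition, with Lepidium sativum as the target, tested at 1 ppm (a higher number here means more inhibition of growth at the concentration tested, a lower number less inhibition of growth), compound 1 gives 51%. Among the measured compounds shown here, that is the lower of the two numbers measured so far. Compound 2 `CCCOC(=O)C(C)ON1C(=O)c2ccccc2C1=O`, which carries a propyl in place of the isopropyl on the oxygen next to the carbonyl group, gives 64% in this assay, and the step of a number 13 percentage points higher from compound 1 to compound 2 (beyond the scatter) lies beyond the scatter. Compound 3 `CCOC(=O)C(C)ON1C(=O)c2ccccc2C1=O` has not yet been measured. It differs from compound 1 by hydrogen in place of methyl on a saturated chain carbon bound to an oxygen next to a carbonyl group and a saturated chain carbon, which turns the isopropyl into an ethyl. For the measured compounds named here, only one measured step bears on this, the change from a branched to a straight chain in a number 13 percentage points higher from compound 1 to compound 2 (beyond the scatter). Because a number 13 percentage points higher from compound 1 to compound 2 (beyond the scatter) was modest and upward, a modest upward step is expected for compound 3 as well, although a shorter chain than propyl is reached here. The expected step for compound 3 is a number 9 percentage points higher from compound 1 to compound 3 (within the scatter). Compound 3 is expected to give 60% in this assay, within a range from 45% to 75%.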

Compound 3, percent growth inhibition at one concentration: 68%
Compound 3: the middle estimate sits 8 percentage points below what was measured; low and high end bracket the measured number.
By their numbers in this assay, from the lowest: compound 1; then compounds 2 and 3 (each within the scatter of the next).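

Taking the methyl off the isopropyl to leave an ethyl gives a number 17 percentage points higher from compound 1 to compound 3 (beyond the scatter) in this assay, so a second unbranched ester, after the propyl of compound 2, stands clear of the branched isopropyl ester of compound 1. Between the two unbranched esters the result is a number 4 percentage points higher from compound 2 to compound 3 (within the scatter), so this assay cannot tell ethyl from propyl at this position, and what shows up among these compounds is the loss of the branch rather than any effect of chain length. Nothing available here explains why the branched ester differs from the unbranched ones.

Still open, going by these compounds, is how far this holds on either side of the series, with a methyl ester or a longer chain such as butyl. On these data alone, a carboxylic acid or an amide in place of the ester is equally open.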